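The source may report more compounds than this note shows. Statements on the series, on what has been measured and on what is new or still open speak of the compounds shown alone.

Working notes on the series. In a functional assay on MCF7 cells (Homo sapiens) for antiproliferative activity, read by MTT assay, with a stated time of 72 h (on this read-out higher numbers stand for weaker inhibition and lower numbers for stronger inhibition), compound 1 `O=c1c(Cl)c(CSC(=S)N2CCOCC2)oc2ccccc12` gives 11100 nM. Compound 3 `O=c1c(CSC(=S)N2CCCCC2)coc2cc(Cl)ccc12` gives 380 nM in this assay. Within the data shown here, compound 2 `O=c1cc(CSC(=S)N2CCCCC2)oc2cc(Cl)ccc12` returns only a limit in this assay, > 25000 nM, so no number stands for it; compound 2 is the one value sitting at the limit of > 25000 nM in this assay, at which 1 of the 3 values shown sits. Among the measured compounds shown here, no two compounds measured here differ in one place, so no measured step is available to lean on. Compound 4 `CC(C)N(C(=S)SCc1cc(=O)c2ccc(Cl)cc2o1)C(C)C` is the next candidate; it differs from compound 2 by diisopropylamino in place of piperidin-1-yl on a thiocarbonyl carbon. With compound 2 known only as a limit, the expected step is a step that the limit leaves unreadable from compound 2 to compound 4, not beyond the scatter in either direction. Compound 4 is estimated at 30000 nM, within 8000 nM to 100000 nM, with a real chance that this assay again reports only a limit.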

Compound 4, half-maximal inhibitory concentration: > 25000 nM
Compound 4: no number, only a limit (the forecaster's own chance of this, stated with the estimate: 60%); the middle value is on the limit's open side.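

Compound 2 and compound 4 both return only a limit, not a number, so no step between them can be read: the limit of > 25000 nM in this assay, at which 2 of the 4 values shown sit.

As far as these compounds go, whether diisopropylamino in place of piperidin-1-yl on a thiocarbonyl carbon shifts the activity at all remains open.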